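This account rests on a few compounds, and the source may have more. Where it says the series, first, only, none or still open, it means among the compounds named here.

Working notes on the series. Compound 1 `CC1=C([Se]CC(OC(=O)[C@@H](CO)NC(=O)OC(C)(C)C)C(=O)NC(C)(C)C)C(=O)c2ccccc2C1=O` is the reference point of the two compounds measured in a functional assay on A-431 cells (Homo sapiens) for cytotoxicity, read by MTT assay, with a stated time of 24 h; a lower number here means a stronger inhibitor, a higher number a weaker inhibitor; in this assay compound 1 gives 2000 nM. Going by the values given here, compound 2 `CC1=C([Se]CC(OC(=O)[C@@H](CO)NC(=O)OC(C)(C)C)C(=O)NCCCCCC(=O)OCc2ccccc2)C(=O)c2ccccc2C1=O` is the only other measured member, and in this assay compound 2 gives 4000 nM. The two numbers lie within the usual scatter of each other, so they show no difference that can be read as a ranking. Among the compounds with values here, no pair of measured compounds differs in one place, so the series carries no measured step to guide the next change.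

Compound 3 `CC1=C([Se]CC(OC(=O)[C@@H](CSSC(C)(C)C)NC(=O)OC(C)(C)C)C(=O)NC(C)(C)C)C(=O)c2ccccc2C1=O` is the unmeasured member. It differs from compound 1 by ((tert-butyl)sulfanyl)sulfanyl in place of hydroxy on a saturated chain carbon, two bonds along the chain from an amide-type nitrogen and a carbonyl carbon. Within the data shown here, with no comparable step among the measured compounds, the expectation for compound 3 is a step from compound 1 of a 1.3-fold higher number from compound 1 to compound 3 (0.10 log units; within the scatter), that is, none beyond the scatter. Compound 3 is accordingly estimated at 2500 nM, with a range from 800 nM to 8000 nM.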

Compound 3, half-maximal inhibitory concentration: 2000 nM
The estimate for compound 3 lay 1.3-fold (0.10 log units) above the measured number; low and high end bracket the measured number.
By their numbers in this assay, from the lowest: compounds 1, 3 and 2 (each within the scatter of the next).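

In this assay, ((tert-butyl)sulfanyl)sulfanyl in place of hydroxy on a saturated chain carbon, two bonds along the chain from an amide-type nitrogen and a carbonyl carbon, gives no change at the digits printed from compound 1 to compound 3 (within the scatter). Going by these compounds alone, this is the first measured one-place step, and at this position the read-out does not separate a group of 1 heavy atom and 1 hydrogen-bond donor from one of 6 heavy atoms and 0 hydrogen-bond donors. No measurement on these compounds accounts for this result.

Going by these compounds, whether an amine, a carboxylic acid or a free thiol at this position would also stay within the scatter in this assay remains open. Also open, on these data alone, is whether the same exchange on compound 2 would give a similar step.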